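A Methoxy Group Added to the Shared Core

The source may hold more compounds than are shown below. What is called first, only, known or untested is meant among the compounds shown, and "the series" means these compounds.

Compound 1 `CCc1ccc(/C=C/[C@@H]2CCCCN2)cc1`: 4.13 ug/mL
Compound 2 `C(=C/[C@@H]1CCCCN1)\c1ccccc1`: 9.15 ug/mL

Both compounds were tested in a functional assay on MCF7 cells (Homo sapiens) for inhibition, read by MTT assay, with a stated time of 24 h; on this read-out higher numbers stand for weaker inhibition and lower numbers for stronger inhibition. Among the compounds with values here, compound 2 gives the highest of the two numbers, 9.15 ug/mL; its only neighbour is compound 1, which gives 4.13 ug/mL. Within the data shown here, the single measured step, a 2.2-fold higher number from compound 1 to compound 2 (0.35 log units; beyond the scatter), shows that removing an alkyl substituent from the aromatic ring pushed the number up by a modest amount, so the bare ring of compound 2 is the weaker of the two.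

Compound 3 `COc1ccccc1/C=C/[C@@H]1CCCCN1` differs from compound 2 by methoxy in place of hydrogen on an aromatic carbon. Among the measured compounds shown here, no measured step covers this exact change: the one known step concerns a different group at a different place on the ring, and it tells only that a substituted ring gave the lower number. On that slim basis a small lowering is the most one can expect, and it may well stay within the scatter. Compound 3 is therefore expected to give 6.5 ug/mL, with a likely range from 3.2 ug/mL to 13 ug/mL. The expected step of a 1.4-fold lower number from compound 2 to compound 3 (0.15 log units; within the scatter) is estimated as a modest lowering at most.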

Compound 3, half-maximal inhibitory concentration: 3.81 ug/mL
Compound 3: middle estimate off by 1.7-fold (0.23 log units), on the high side; low and high end bracket the measured number.
By their numbers in this assay, from the lowest: compounds 3 and 1 (each within the scatter of the next); then compound 2.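

In this assay, methoxy in place of hydrogen on the aromatic carbon ortho to a group of 8 heavy atoms gives a 2.4-fold lower number from compound 2 to compound 3 (0.38 log units; beyond the scatter) and so shows that this position responds to substitution, with a modest step that still lies beyond the scatter. Until now the only evidence for a substituent lowering the number came from the ethyl group of compound 1, so compound 3 adds a second, different group that does the same; among the three compounds shown, both substituted rings give lower numbers than the bare ring of compound 2, and none goes against this. Nothing measured here accounts for why the number falls with methoxy at this position.

As far as these compounds go, what remains open is whether this lowering belongs to methoxy itself or would appear with other groups on the same carbon, such as a hydroxyl group, a chlorine atom or an amine. From the compounds shown here alone, it is also open whether methoxy would give a similar step on the other carbons of the ring, and whether a longer chain such as ethoxy or propoxy would lower the number further or raise it again.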